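The compounds below may be only part of what the source reports. "The series", "measured", "known", "first", "only" and "open" are said of these compounds alone.

Series notes, measured in a functional assay on MOLT-4 cells (Homo sapiens) for inhibition; on this read-out lower numbers stand for stronger inhibition and higher numbers for weaker inhibition:

- Compound 1 `O=C1/C(=C/c2ccc(Br)cc2)Cc2ccccc21`: > 500000 nM
- Compound 2 `O=C1/C(=C/c2cccc(Cl)c2)CCCc2ccccc21`: 23800 nM

The entry for compound 1 is a limit of the assay, not a number. For the measured compounds named here, compound 2, at 23800 nM, holds the only actual number so far in this assay, so it can't yet be ranked against a second measured number.

Next is compound 3 `O=C1/C(=C/c2cccc([N+](=O)[O-])c2)CCCc2ccccc21`, which carries nitro in place of chloro on an aromatic carbon, meta to a large group: nitro in place of chloro on an aromatic carbon. Going by the values given here, no measured step bears on this exchange, so there is no basis for calling a direction. The expected change is none beyond the scatter, and the estimated step is a 1.2-fold lower number from compound 2 to compound 3 (0.08 log units; within the scatter). The estimate for compound 3 is 20000 nM, with an expected range of 6000 nM to 70000 nM.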

Compound 3, half-maximal inhibitory concentration: 8820 nM
For compound 3 the middle estimate is 2.3-fold (0.36 log units) above the measured one; the measured number falls inside the stated range.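

At the aromatic carbon meta to a large group, the substituent affects the read-out in this assay: nitro in place of chloro gives a 2.7-fold lower number from compound 2 to compound 3 (0.43 log units; beyond the scatter). For the compounds shown here, this is the first step between two actual numbers, and it shows that a larger group carrying hydrogen-bond acceptors is accepted here without loss of inhibition. No measurement shown accounts for the size of this step, so the feature of nitro responsible for it remains unidentified.

From the compounds shown here alone, it remains open whether an amine or a nitrile on the same aromatic carbon would continue this trend or reverse it. Going by these compounds, it is also open whether nitro gives a step of similar size when it sits elsewhere on the same aromatic ring.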